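The compounds below may be only part of what the source reports. "The series", "measured", "known", "first", "only" and "open" are said of these compounds alone.

Compounds measured so far:
compound 1, `CC(C)=CCC1Cc2c(OC(=O)Nc3ccc(F)cc3F)cc(=O)n(CCCO)c2CC1(C)C`, gives 0%;
compound 2, `CC(C)=CCC1Cc2c(OC(=O)Nc3ccc(F)c(F)c3)cc(=O)n(CCCO)c2CC1(C)C`, gives 0%;
compound 3, `CC(C)=CCC/C(C)=C/CC1Cc2c(OC(=O)Nc3ccc(F)cc3F)cc(=O)n(CCCO)c2CC1(C)C`, gives 15.6%.

All three were tested in a functional assay on PANC-1 cells (Homo sapiens) for inhibition, read by MTT assay, with a stated time of 24 h, tested at 10 uM; on this read-out higher numbers stand for more inhibition at the one concentration tested (going by the name of the read-out) and lower numbers for less inhibition. Compound 1 and compound 2 differ by 3,4-difluorophenyl in place of 2,4-difluorophenyl on an amide-type nitrogen, and the step is no change at the digits printed from compound 1 to compound 2 (within the scatter). Compound 3 differs from compound 1 by 3-methylbut-2-en-1-yl in place of hydrogen on a saturated chain carbon bound to a double-bonded chain carbon, and here the step is a number 15.6 percentage points higher from compound 1 to compound 3 (beyond the scatter), so compound 3 stands highest of the three.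

Compound 4, `CC(C)=CCC/C(C)=C/CC1Cc2c(OC(=O)Nc3ccc(F)c(F)c3)cc(=O)n(CCCO)c2CC1(C)C`, has not been measured yet. It differs from compound 3 by 3,4-difluorophenyl in place of 2,4-difluorophenyl on an amide-type nitrogen, the same change as from compound 1 to compound 2, made on the same place with the same neighbours, while the core of compound 3 carries the longer chain described above. Because that change gave no change at the digits printed from compound 1 to compound 2 (within the scatter), the step from compound 3 to compound 4 is expected to be about a number 1.6 percentage points lower from compound 3 to compound 4 (within the scatter). Compound 4 is therefore estimated at 14%, likely between 0% and 30%.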

Compound 4, a percentage reported as inhibition, at one concentration (the size of the read-out at that concentration, not a potency): 4.8%
Compound 4: middle estimate off by 9.2 percentage points, on the high side, and the stated range covers the measured number.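

Replacing 2,4-difluorophenyl with 3,4-difluorophenyl on the core with the longer chain gives a number 10.8 percentage points lower from compound 3 to compound 4 (beyond the scatter), and adding 3-methylbut-2-en-1-yl to the core carrying 3,4-difluorophenyl gives a number 4.8 percentage points higher from compound 2 to compound 4 (within the scatter). Across the two cores, the two fluorine patterns give steps that cannot be told apart: the same change on two cores in this assay, no change at the digits printed (within the scatter) from compound 1 to compound 2 and a number 10.8 percentage points lower (beyond the scatter) from compound 3 to compound 4, 10.8 percentage points apart, within the scatter of two such steps

The added chain likewise shows no clear dependence on the core, but two pairs tested at one concentration do not prove that either change carries over with the same size: the same change on two cores in this assay, a number 15.6 percentage points higher (beyond the scatter) from compound 1 to compound 3 and a number 4.8 percentage points higher (within the scatter) from compound 2 to compound 4, 10.8 percentage points apart, within the scatter of two such steps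

The compounds shown leave open how other groups on the amide-type nitrogen, such as a plain phenyl or a pyridyl ring, would behave. They also leave open what a still longer chain would do.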